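Acyl chain extension in an adenosine-derived amide series

The source may report more compounds than this note shows. Statements on the series, on what has been measured and on what is new or still open speak of the compounds shown alone.

Measured compounds:
compound 1 `CC(=O)NC/C=C\CN(C)C[C@H]1O[C@@H](n2cnc3c(N)ncnc32)[C@H](O)[C@@H]1O` gives > 1.5 h (a limit of the assay).
compound 2 `CCC(=O)NC/C=C\CN(C)C[C@H]1O[C@@H](n2cnc3c(N)ncnc32)[C@H](O)[C@@H]1O` gives > 1.5 h (a limit of the assay).
compound 3 `CCC(=O)NC/C=C\CN(C)C[C@H]1O[C@@H](n2cnc3c(N)ncnc32)[C@H](OC(C)=O)[C@@H]1OC(C)=O` gives 1.25 h.

In an ADME assay on microsomes from liver (Homo sapiens) for metabolic stability, read by LC-MS, using NADPH, tested at 1 uM (on this read-out higher numbers stand for a longer-lived compound and lower numbers for a shorter-lived compound), compound 1 reaches only the limit of the assay, which is not a number. Compound 2 likewise sits at the limit of the assay in this assay. The change between them is methyl in place of hydrogen on a saturated chain carbon bound to a carbonyl carbon and gives a step that the two limits leave unreadable from compound 1 to compound 2. With both values resting at the limit of > 1.5 h in this assay, at which 2 of the 3 values shown sit, the size of that step cannot be read.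

Compound 3 carries the same acyl chain as compound 2 but differs from compound 1 in more than one place; the difference between the two cores is not broken down here. Compound 3 is the only one of the three with a number in this assay.

Compound 4 `CCCC(=O)NC/C=C\CN(C)C[C@H]1O[C@@H](n2cnc3c(N)ncnc32)[C@H](OC(C)=O)[C@@H]1OC(C)=O` remains to be measured. It differs from compound 3 by methyl in place of hydrogen on a saturated chain carbon, two bonds along the chain from a carbonyl carbon. Within the data shown here, this is the same kind of change as the one from compound 1 to compound 2, not the same: there the methyl entered on a saturated chain carbon bound to a carbonyl carbon, here it enters on a saturated chain carbon, two bonds along the chain from a carbonyl carbon. Since the earlier step was unreadable, the expectation for compound 4 rests on compound 3 and its value 1.25 h alone. The step from compound 3 to compound 4 in this assay is expected to be a 1.0-fold higher number from compound 3 to compound 4 (0.02 log units; within the scatter), within the usual scatter. Compound 4 is therefore estimated at 1.3 h, with a range from 0.7 h to 2.5 h, and a fair chance that the assay again reports only a limit.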

Compound 4, half-life: 0.85 h
For compound 4 the middle estimate is 1.5-fold (0.18 log units) above the measured one; measured number inside the range.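

Going from propanoyl to propylcarbonyl gives, in this assay, a 1.5-fold lower number from compound 3 to compound 4 (0.17 log units; within the scatter), so on this core the methyl on a saturated chain carbon, two bonds along the chain from a carbonyl carbon, moves the read-out by no more than the usual scatter. Among these compounds, on the core of compound 1, the step to compound 2 cannot be read, and that methyl also sits in a different place, on a saturated chain carbon bound to a carbonyl carbon, so the two cores offer no pair of readable steps to compare: the limit of > 1.5 h in this assay, at which 2 of the 4 values shown sit. The result is therefore one pair on one core, and it does not show whether the change carries from one core to the other, either in size or in direction.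

Still open, on these data alone, is whether a longer chain, an amine or a carboxylic acid in place of the propylcarbonyl group would give a step beyond the scatter on the core of compound 3 in this assay. Also open, as far as these compounds go, is how far compound 1 and compound 2 stand apart, since neither has a number in this assay, only a limit of the assay.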